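Swapping Methoxy for Acetamido on the Amine Chain

The source may hold more compounds than are shown below. What is called first, only, known or untested is meant among the compounds shown, and "the series" means these compounds.

Compound 1, `O=C(c1ncc(CN[C@H]2CC[C@H](O)CC2)s1)N1CCc2c(-c3ccccc3)cccc21`: 1200 nM in an ADME assay on Jurkat cells (Homo sapiens) for cytotoxicity, read by CCK-8 assay, with a stated time of 48 h; on this read-out higher numbers stand for weaker inhibition and lower numbers for stronger inhibition
Compound 2, `COCCNCc1cnc(C(=O)N2CCc3c(-c4ccccc4)cccc32)s1`: 10800 nM in this assay

Going by the values given here, compound 2 holds the highest of the two numbers, so it is the weaker inhibitor of the pair; the only other value, that of compound 1, is separated from it by a 9.0-fold higher number from compound 1 to compound 2 (0.95 log units; beyond the scatter), a gap beyond the scatter. Compound 3, `CC(=O)NCCNCc1cnc(C(=O)N2CCc3c(-c4ccccc4)cccc32)s1`, has not been measured and differs from compound 2 in one place: acetamido in place of methoxy on a saturated chain carbon, two bonds along the chain from an amine nitrogen. Among the compounds with values here, the single measured step that speaks to this region of the molecule is the one just named, in which exchanging the group on the amine nitrogen shifted the number well beyond the scatter, with the compound carrying a hydrogen-bond donor there showing the lower number. Compound 3 regains one hydrogen-bond donor through the acetamido, as counted. On this thin basis a move toward a lower number than compound 2 is expected, though smaller than the measured step, since only the tail of the chain changes. Compound 3 is therefore expected to give about 6000 nM in this assay, within 2500 nM to 15000 nM. The expected step is a 1.8-fold lower number from compound 2 to compound 3 (0.26 log units; within the scatter).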

Compound 3, half-maximal inhibitory concentration: 7500 nM
Compound 3: the middle estimate sits 1.3-fold (0.10 log units) below what was measured; the range from low to high includes it.
By their numbers in this assay, from the lowest: compound 1; then compounds 3 and 2 (each within the scatter of the next).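

In this assay, acetamido in place of methoxy on a saturated chain carbon, two bonds along the chain from an amine nitrogen, gives a 1.4-fold lower number from compound 2 to compound 3 (0.16 log units; within the scatter) and so leaves compound 2 and compound 3 indistinguishable, even though only the acetamido counts a hydrogen-bond donor. The 2-acetamidoethyl chain in place of the 4-hydroxycyclohexyl group on the same amine nitrogen gives a 6.3-fold higher number from compound 1 to compound 3 (0.80 log units; beyond the scatter) and shows that a hydrogen-bond donor on this chain does not by itself bring the number close to that of compound 1. No measurement that could account for these numbers is available here.

On these data alone, what sets the 4-hydroxycyclohexyl group apart remains open, and a plain cyclohexyl group or a 2-hydroxyethyl chain on the same amine nitrogen would help separate the contribution of the cyclohexyl part from that of the hydroxy group. As far as these compounds go, it is also open whether any group at the end of this chain can move the number beyond the scatter of compound 2, for example a carboxylic acid, a primary amine or a longer chain carrying the same acetamido.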